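This account rests on a few compounds, and the source may have more. Where it says the series, first, only, none or still open, it means among the compounds named here.

Three pyrimidinedione-bearing alkynes have been examined in an ADME assay on MRC5 cells (Homo sapiens) for cytotoxicity, read by MTT assay; a lower number here means that less compound is tolerated, a higher number that more compound is tolerated. Compound 1, `C[Si](C)(C)C#Cc1c[nH]c(=O)[nH]c1=O`, carries a silicon-containing group on the far end of the triple bond; in this assay compound 1 gives 124000 nM. Compound 2, `CCCCCCC#Cc1c[nH]c(=O)[nH]c1=O`, carries a hexyl chain in the same place, and in this assay compound 2 gives 94900 nM. Compound 3, `O=c1[nH]cc(C#CC(O)c2ccccc2)c(=O)[nH]1`, carries a hydroxylated benzylic group there, and in this assay compound 3 gives 38400 nM.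

Compound 1 thus has the highest of the three numbers, but its gap to compound 2 lies within the usual scatter, so no order between those two can be claimed; its gap to compound 3 is larger and lies beyond the scatter.

Compound 4, `O=c1[nH]cc(C#CC2CC2)c(=O)[nH]1`, differs from compound 1 in one place: a group of 3 heavy atoms (3 carbon; one three-membered non-aromatic ring of carbon only) in place of a group of 4 heavy atoms (3 carbon, 1 silicon; no ring), on a triple-bonded carbon. Going by the values given here, no measured pair shows what such a change does here. Given that compound 2, with its own chain-like substituent at this position, shows 94900 nM, the step of a 1.2-fold lower number from compound 1 to compound 4 (0.09 log units; within the scatter) is expected to stay within the scatter. Compound 4 is estimated at 100000 nM, within a range of 50000 nM to 200000 nM.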

Compound 4, half-maximal cytotoxic concentration: 101000 nM
Beside the measured number, compound 4's estimate is 1.0-fold (0.00 log units) below it; the measured number falls inside the stated range.
By their numbers in this assay, from the lowest: compound 3; then compounds 2, 4 and 1 (each within the scatter of the next).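

Read in this assay, replacing the group of 3 carbon and 1 silicon atoms with cyclopropyl on the triple-bonded carbon gives a 1.2-fold lower number from compound 1 to compound 4 (0.09 log units; within the scatter), the first direct one-place comparison at this position. In this pair, then, the silicon-containing group can give way to a small all-carbon ring with no change that can be claimed, so silicon is not needed to keep the number at this level. No measurement at hand gives a reason for this result.

From the compounds shown here alone, it remains open whether a larger ring such as cyclohexyl, or a chain ending in an amine or a carboxylic acid, on the same triple-bonded carbon would keep the number at this level. The compounds shown also leave open what a change to the shared core would do.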